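A few compounds are considered here, and "the series" means these few. Any claim that something is new, unique, unknown or untested is made for them only; others in the source may bear on it.

Measured compounds in a functional assay on MCF7 cells (Homo sapiens), read by MTT assay, with a stated time of 48 h; on this read-out lower numbers stand for stronger inhibition and higher numbers for weaker inhibition:
- compound 1, `CCn1c(C(=O)NCCCN(C)C)ccc1C(CC)(CC)c1ccc(OCC(=O)C(C)(C)C)c(C)c1`: 340 nM
- compound 2, `CCn1c(C(=O)NCCCN(C)C)ccc1C(CC)(CC)c1ccc(OCC(O)C(C)(C)C)c(C)c1`: 490 nM
- compound 3, `CCn1c(C(=O)NCCN)ccc1C(CC)(CC)c1ccc(OCC(O)C(C)(C)C)c(C)c1`: 5.9 nM

Compound 2 gives the highest number of the three in this assay; the gap to its nearest neighbour is a 1.4-fold higher number from compound 1 to compound 2 (0.16 log units; within the scatter), while compound 3 stands far off, at an 83-fold lower number from compound 2 to compound 3 (1.92 log units; beyond the scatter).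

Compound 4, `CC[C@@H](C)[C@H](NC(=O)c1ccc(C(CC)(CC)c2ccc(OCC(O)C(C)(C)C)c(C)c2)n1CC)C(=O)O`, has not yet been measured in this assay. It differs from compound 2 at the amide-type nitrogen: 1-carboxy-2-methylbutyl in place of 3-(dimethylamino)propyl on an amide-type nitrogen. For the measured compounds named here, the only measured step touching that nitrogen is an 83-fold lower number from compound 2 to compound 3 (1.92 log units; beyond the scatter), where the 3-(dimethylamino)propyl arm was shortened to an aminoethyl arm and the number fell sharply; it shows that this arm governs the read-out, but it leads toward an amine, not toward a 1-carboxy-2-methylbutyl group. The step from compound 1 to compound 2 concerns the other end of the molecule and says nothing here. Going by the values given here, no measured compound carries a carboxylic acid, so the direction is uncertain; the expected step for compound 4 is a 3.1-fold higher number from compound 2 to compound 4 (0.49 log units; beyond the scatter), with a wide range. Compound 4 is estimated at 1500 nM, from 150 nM to 12000 nM.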

Compound 4, half-maximal inhibitory concentration: 2000 nM
Compound 4: middle estimate off by 1.3-fold (0.12 log units), on the low side, and the stated range covers the measured number.
By their numbers in this assay, from the lowest: compound 3; then compounds 1 and 2 (each within the scatter of the next); then compound 4.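

On the amide-type nitrogen, 1-carboxy-2-methylbutyl in place of 3-(dimethylamino)propyl gives a 4.1-fold higher number from compound 2 to compound 4 (0.61 log units; beyond the scatter) in this assay, so changes at this position can raise the number as well as lower it. Set against the 2-aminoethyl arm, the same group gives a 340-fold higher number from compound 3 to compound 4 (2.53 log units; beyond the scatter), a wider span at this one position than the earlier step from the 3-(dimethylamino)propyl arm to the 2-aminoethyl arm had shown. Nothing available bears on why these arms differ.

Still open, going by these compounds, is which part of the 1-carboxy-2-methylbutyl group carries the step: the carboxylic acid, the branched chain or the two defined stereocentres. A methyl ester or an unbranched chain ending in a carboxylic acid would separate these, and 3-aminopropyl and 2-(dimethylamino)ethyl arms would separate chain length from the methyl groups on the amine.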